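Cyclopropyl in place of 4-chloro-2-fluorophenyl on the amide-type nitrogen

The compounds below may be only part of what the source reports. "The series", "measured", "known", "first", "only" and "open" are said of these compounds alone.

In an in vitro ADME assay on microsomes from liver (Homo sapiens) for pharmacokinetics, read by LC-MS, with a stated time of 10 min, tested at 1 uM (a higher number here means faster removal of the compound, a lower number slower removal), compound 1 (`CN1C[C@H](C(=O)Nc2ccccc2)[C@@H](c2ccc(/C=C/C(=O)Nc3ccccc3N)cc2)C1`) gives 7 mL/min/kg and compound 2 (`CN1C[C@H](C(=O)Nc2ccc(Cl)cc2F)[C@@H](c2ccc(/C=C/C(=O)Nc3ccccc3N)cc2)C1`) gives 11 mL/min/kg. Compound 2 therefore stands level with compound 1, the two values lying within the scatter of each other.

Compound 3 (`CN1C[C@H](C(=O)NC2CC2)[C@@H](c2ccc(/C=C/C(=O)Nc3ccccc3N)cc2)C1`) carries cyclopropyl in place of 4-chloro-2-fluorophenyl on an amide-type nitrogen. Within the data shown here, the one measured step that bears on this change sits at the same place and swaps phenyl for 4-chloro-2-fluorophenyl: a 1.6-fold higher number from compound 1 to compound 2 (0.20 log units; within the scatter). That step shows no clear response in this assay to the exchange at this nitrogen. Among the measured compounds shown here, no measured compound has a non-aromatic ring there, so the new group lies outside the measured range of structures and the expectation remains loose.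

The expected 1.4-fold lower number from compound 2 to compound 3 (0.14 log units; within the scatter) stays within the scatter, with no real change foreseen. For compound 3 the estimated clearance is 8 mL/min/kg, with an expected range from 4 mL/min/kg to 16 mL/min/kg.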

Compound 3, clearance: 10 mL/min/kg
Compound 3: middle estimate off by 1.3-fold (0.10 log units), on the low side, and the stated range covers the measured number.
By their numbers in this assay, from the lowest: compounds 1, 3 and 2 (each within the scatter of the next).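

At the amide-type nitrogen, cyclopropyl brings the first non-aromatic ring to this position, and in this assay the step to it from the substituted aryl group is small, with a 1.1-fold lower number from compound 2 to compound 3 (0.04 log units; within the scatter) and, against the unsubstituted aryl group, a 1.4-fold higher number from compound 1 to compound 3 (0.15 log units; within the scatter). Until now the position had been read only across two aromatic groups, whereas these steps show that replacing the aromatic ring with a three-membered carbon ring, and going from 8 heavy atoms in 4-chloro-2-fluorophenyl to 3 in cyclopropyl, does not separate the compounds beyond the scatter in this read-out. Nothing in hand explains why the three values stay so close.

Still open, from the compounds shown here alone, is whether a longer chain such as n-butyl, or a group carrying an amine or a carboxylic acid, on the amide-type nitrogen would move clearance beyond the scatter. Going by these compounds, the three compounds speak only to this one place, so the response of clearance to changes elsewhere on the shared core also remains open.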